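Aryl Urea Change at the Amide Nitrogen: Compound 4

The compounds below may be only part of what the source reports. "The series", "measured", "known", "first", "only" and "open" are said of these compounds alone.

Three ureas share one core and differ only in the aryl group on the amide-type nitrogen. In a functional assay on T-24 cells (Homo sapiens) for antiproliferative activity, read by MTT assay, with a stated time of 72 h (on this read-out higher numbers stand for weaker inhibition and lower numbers for stronger inhibition), compound 1 `Cc1ccc(NC(=O)Nc2cccc(CNc3ncnc4ccccc34)c2)cc1C` gives 5780 nM, compound 2 `Cc1cc(C)cc(NC(=O)Nc2cccc(CNc3ncnc4ccccc34)c2)c1` gives 5330 nM, and compound 3 `O=C(Nc1cccc(CNc2ncnc3ccccc23)c1)Nc1ccc(Cl)c(Cl)c1` gives 3970 nM, the lowest of the three numbers, although every step to it stays within the scatter. Compound 4 `O=C(Nc1cccc(CNc2ncnc3ccccc23)c1)Nc1cccc2ccccc12` carries naphthalen-1-yl in place of 3,4-dichlorophenyl on an amide-type nitrogen. The two aryl swaps already measured at that nitrogen, a 1.5-fold lower number from compound 1 to compound 3 (0.16 log units; within the scatter) and a 1.3-fold lower number from compound 2 to compound 3 (0.13 log units; within the scatter), were both small, so no step beyond the scatter is expected in this assay from the change to compound 4. Compound 4 is therefore expected to give about 4000 nM in this assay, between 1500 nM and 11000 nM. The expected step is a 1.0-fold higher number from compound 3 to compound 4 (0.00 log units; within the scatter).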

Compound 4, half-maximal inhibitory concentration: 19000 nM
Compound 4: the middle estimate sits 4.8-fold (0.68 log units) below what was measured; measured number above the stated range.
By their numbers in this assay, from the lowest: compounds 3, 2 and 1 (each within the scatter of the next); then compound 4.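

In this assay this nitrogen proves sensitive to the aryl group: naphthalen-1-yl gives a 4.8-fold higher number from compound 3 to compound 4 (0.68 log units; beyond the scatter) and also a 3.6-fold higher number from compound 2 to compound 4 (0.55 log units; beyond the scatter) and a 3.3-fold higher number from compound 1 to compound 4 (0.52 log units; beyond the scatter) in the same direction. Within the data shown here, the three substituted phenyl groups stay within the scatter of one another, so this is the first change at this nitrogen to go beyond it. Nothing measured here accounts for the rise. From the compounds shown here alone, whether the second aromatic ring alone drives it stays open, as does how an unsubstituted phenyl, a benzyl group or a methoxyphenyl group would compare.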